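The compounds below may be only part of what the source reports. "The series", "measured", "known", "first", "only" and "open" are said of these compounds alone.

Measured so far in a functional assay on HEK293 cells for agonist activity at Vasopressin V2 receptor (Homo sapiens), read by a luciferase reporter and cAMP accumulation; a higher number here means that more compound is needed for the effect, a lower number that less compound is needed:
- compound 1, `Cc1cc(C(=O)N2CCCCc3ccccc32)ccc1CNC(=O)Nc1ccccc1`: 130 nM
- compound 2, `Cc1cc(C(=O)N2CCCCc3ccccc32)ccc1CNC(=O)NCC(=O)OC(C)(C)C`: 120 nM
- compound 3, `CCN(CC)C(=O)[C@@H]1CCCN1C(=O)NCc1ccc(C(=O)N2CCCCc3ccccc32)cc1C`: 350 nM

Compound 3 stands highest of the three numbers in this assay; its nearest neighbour is compound 1 and the furthest compound 2, both steps to it beyond the scatter. The two steps leading into compound 3 are a 2.7-fold higher number from compound 1 to compound 3 (0.43 log units; beyond the scatter) and a 2.9-fold higher number from compound 2 to compound 3 (0.46 log units; beyond the scatter), each a modest rise when the 2-(diethylcarbamoyl)pyrrolidin-1-yl group is put on the carbonyl carbon of the urea. The step between compound 1 and compound 2, a 1.1-fold lower number from compound 1 to compound 2 (0.03 log units; within the scatter), is within the scatter.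

Compound 4, `Cc1cc(C(=O)N2CCCCc3ccccc32)ccc1CNC(=O)N1CCC[C@@H]1C(=O)N(C)C`, keeps the shared core and the pyrrolidine urea of compound 3 and changes only the carbamoyl substituent: 2-(dimethylcarbamoyl)pyrrolidin-1-yl in place of 2-(diethylcarbamoyl)pyrrolidin-1-yl on a carbonyl carbon. Within the data shown here, none of the measured steps touches this carbamoyl group, so no step speaks directly to it; the measured steps only show that the pyrrolidine urea as a whole sits modestly above the anilino and glycine ester ureas. Shortening the two ethyl groups to methyl is a small change at a position not yet varied, and no shift beyond the scatter is expected in this assay, no change at the digits printed from compound 3 to compound 4 (within the scatter). Compound 4 is therefore estimated at 350 nM, with a range of 150 nM to 800 nM.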

Compound 4, half-maximal effective concentration: 380 nM
For compound 4 the middle estimate is 1.1-fold (0.04 log units) below the measured one, and the stated range covers the measured number.
By their numbers in this assay, from the lowest: compounds 2 and 1 (each within the scatter of the next); then compounds 3 and 4 (each within the scatter of the next).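

Among these compounds, replacing 2-(diethylcarbamoyl)pyrrolidin-1-yl with 2-(dimethylcarbamoyl)pyrrolidin-1-yl on the carbonyl carbon gives a 1.1-fold higher number from compound 3 to compound 4 (0.04 log units; within the scatter) in this assay and is the first variation of the carbamoyl substituent, which tolerates this change without a shift beyond the scatter. The rise of the pyrrolidine ureas over the other two ureas also holds with the dimethylcarbamoyl group, at a 3.2-fold higher number from compound 2 to compound 4 (0.50 log units; beyond the scatter) and a 2.9-fold higher number from compound 1 to compound 4 (0.47 log units; beyond the scatter), so that modest gap is not tied to the diethylcarbamoyl group. No measurement available here offers an explanation for either the flat step or the modest gaps.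

The compounds shown leave open whether the carbamoyl group can be exchanged more deeply than an ethyl-to-methyl change, for instance for a free carboxylic acid, a primary amide or a piperidine amide. Also open, going by these compounds, are the opposite configuration at the defined stereocentre of the pyrrolidine and whether any such group would bring the pyrrolidine ureas level with the anilino urea of compound 1.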